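This account rests on a few compounds, and the source may have more. Where it says the series, first, only, none or still open, it means among the compounds named here.

Compound 1 `COC(=O)c1c[nH]c2cc(OCCOc3ccccc3)c(OC)cc2c1=O`: > 20000 nM
Compound 2 `COC(=O)c1c[nH]c2ccc(OCc3ccccc3)cc2c1=O`: 7590 nM

Within the data shown here, in an ADME assay on J774 cells (Mus musculus) for cytotoxicity (a lower number here means that less compound is needed, a higher number that more compound is needed for the effect), compound 2 gives 7590 nM, the only actual number among the measured compounds. Compound 1 gives > 20000 nM, which is a limit of the assay and not a number. The two compounds differ in more than one place, so their values do not isolate any single structural change.

Compound 3 `COC(=O)c1c[nH]c2ccc(OCCCc3ccccc3)cc2c1=O` has phenethyl in place of phenyl on a saturated chain carbon bound to an oxygen on an aromatic ring. Among the measured compounds shown here, no measured step bears on this change, so in this assay no step beyond the scatter is expected, in either direction. Compound 3 is estimated at 7000 nM, with an expected range of 2500 nM to 20000 nM. This estimate means an expected step of a 1.1-fold lower number from compound 2 to compound 3 (0.04 log units; within the scatter).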

Compound 3, half-maximal effective concentration: 17100 nM
For compound 3 the middle estimate is 2.4-fold (0.39 log units) below the measured one; the range from low to high includes it.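

Among these compounds, compound 2 and compound 3 form the first pair that differs in one place, so the effect of a single change can now be read: with phenethyl in place of phenyl on a saturated chain carbon bound to an oxygen on an aromatic ring, this assay shows a 2.3-fold higher number from compound 2 to compound 3 (0.35 log units; beyond the scatter). This place therefore responds to the change, and more compound is needed for the cytotoxic effect with phenethyl than with phenyl. This rests on one pair, so it is not yet a trend, and little room remains in this direction: the limit of > 20000 nM in this assay, at which 1 of the 3 values shown sits.

On these data alone, it remains open whether a longer chain, an amine or a carboxylic acid at this place would move the number further. As far as these compounds go, it is also open whether the same step would hold on the core of compound 1.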